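This account rests on a few compounds, and the source may have more. Where it says the series, first, only, none or still open, it means among the compounds named here.

Working notes on the series. Among the measured compounds shown here, compound 2 `CSc1nc(-c2ccc(F)cc2)c(-c2ccnc(NC(C)CCc3ccccc3)c2)[nH]1` stands highest of the two numbers so far: in an assay on isolated protein for inhibition of MAP kinase-activated protein kinase 2 (Homo sapiens), tested at 10 uM (a higher number here means more inhibition at the concentration tested (going by the name of the read-out), a lower number less inhibition), compound 2 gives 17%, while compound 1 `CSc1nc(-c2ccc(F)cc2)c(-c2ccnc(NC3CCc4ccccc43)c2)[nH]1` gives 0% in this assay. For the measured compounds named here, the single measured step, a number 17 percentage points higher from compound 1 to compound 2 (beyond the scatter), came from exchanging the group on the nitrogen on the aromatic ring, and it is the only comparison that bears on the next compound. Compound 3 `CCC(Nc1cc(-c2[nH]c(SC)nc2-c2ccc(F)cc2)ccn1)c1ccccc1` differs from compound 2 in the same place: 1-phenylpropyl in place of 1-methyl-3-phenylpropyl on a nitrogen on an aromatic ring. Both groups carry one six-membered aromatic ring of carbon only and differ by one carbon. Going by the values given here, with only one step to draw on, and that step modest, no firm direction can be read; a step within the scatter is expected, a number 2 percentage points lower from compound 2 to compound 3 (within the scatter). Compound 3 is therefore estimated to give 15% in this assay, with a range from 0% to 35%.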

Compound 3, a percentage reported as inhibition, at one concentration (the size of the read-out at that concentration, not a potency): 21%
Estimate against measurement, compound 3: 6 percentage points below; the measured number falls inside the stated range.
By their numbers in this assay, from the lowest: compound 1; then compounds 2 and 3 (each within the scatter of the next).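

In this assay, exchanging 1-methyl-3-phenylpropyl for 1-phenylpropyl on a nitrogen on an aromatic ring gives a number 4 percentage points higher from compound 2 to compound 3 (within the scatter) and so does not separate these two groups, although both carry one six-membered aromatic ring of carbon only. Against 2,3-dihydro-1H-inden-1-yl, 1-phenylpropyl gives a number 21 percentage points higher from compound 1 to compound 3 (beyond the scatter) and this second modest step beyond the scatter leaves compound 1 alone at the low end of the three compounds. No measurement at hand bears on the reason for this difference.

Open, as far as these compounds go, is whether a benzyl or cyclohexyl group in this place would stand with compound 1 or with compound 2 and compound 3. Also open, from the compounds shown here alone, is whether an amine, a carboxylic acid or a longer chain on this nitrogen would move the number beyond the scatter of compound 2 and compound 3.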